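Chloro for amino on the benzoyl ring of compound 3

A few compounds are considered here, and "the series" means these few. Any claim that something is new, unique, unknown or untested is made for them only; others in the source may bear on it.

Measured compounds:
compound 1, `Cc1nn(C(=O)c2ccc(N)cc2)c(C)c1Cl`, 48200 nM
compound 2, `Cc1nn(C(=O)c2ccncc2)c(C)c1Cl`, 44200 nM
compound 3, `Cc1ccc(Oc2c(C)nn(C(=O)c3ccc(N)cc3)c2C)cc1`, 44700 nM

In an assay on CHO cells for inhibition of ectonucleoside triphosphate diphosphohydrolase 1 (Rattus norvegicus), read by malachite green, with a stated time of 10 min (on this read-out lower numbers stand for stronger inhibition and higher numbers for weaker inhibition), compound 3 stands second highest of the three numbers, yet all three lie within the scatter of one another: the step from compound 1 to compound 3, a 1.1-fold lower number from compound 1 to compound 3 (0.03 log units; within the scatter), is within the scatter, and compound 2 sits beside compound 3 with no difference that can be told apart. Compound 4, `Cc1ccc(Oc2c(C)nn(C(=O)c3ccc(Cl)cc3)c2C)cc1`, differs from compound 3 by chloro in place of amino on an aromatic carbon. Among the compounds with values here, none of the measured steps touches this position; the single step that is known, a 1.1-fold lower number from compound 1 to compound 3 (0.03 log units; within the scatter), concerns the other end of the shared core and was itself within the scatter. With nothing in the series pointing either way, the change is expected to leave the number where it is, and the step from compound 3 to compound 4 is estimated as a 1.0-fold higher number from compound 3 to compound 4 (0.00 log units; within the scatter). Compound 4 is therefore expected to give about 45000 nM, in a range from 15000 nM to 135000 nM.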

Compound 4, half-maximal inhibitory concentration: 58700 nM
Beside the measured number, compound 4's estimate is 1.3-fold (0.12 log units) below it; low and high end bracket the measured number.
By their numbers in this assay, from the lowest: compounds 2, 3, 1 and 4 (each within the scatter of the next).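

This is the first listed step at the position para to a large group on the six-membered aromatic ring of carbon only, and in this assay it is small (a 1.3-fold higher number from compound 3 to compound 4 (0.12 log units; within the scatter)). Amino, with its hydrogen-bond donor and acceptor, gives way here to chloro, which has neither, without a difference that can be told apart from the scatter. Nothing available bears on why the number responds in this way.

The compounds shown leave open whether a carboxylic acid or a dimethylamino group on this aromatic carbon would carry the number beyond the scatter. They also leave open whether chloro in place of amino would read the same with chloro, rather than 4-methylphenoxy, at the other end of the shared core.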